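A second fluoro on compound 3

This account rests on a few compounds, and the source may have more. Where it says the series, first, only, none or still open, it means among the compounds named here.

In an ADME assay on Raji cells (Homo sapiens) for cytotoxicity, with a stated time of 72 h (a lower number here means that less compound is needed, a higher number that more compound is needed for the effect), compound 1 (`Cc1cc(NC(=O)Nc2cccc(C(N)=O)c2)c2ccccc2n1`) is reported only as a limit, > 25000 nM. Compound 2 (`Cc1ccc(NC(=O)Nc2cc(C)nc3ccccc23)cc1`) likewise gives only a limit, > 25000 nM. Compound 3 (`Cc1cc(NC(=O)Nc2cccc(F)c2)c2ccccc2n1`) also stands at a limit, > 25000 nM, and so has no number of its own in this assay.

Compound 4 (`Cc1cc(NC(=O)Nc2cc(F)cc(F)c2)c2ccccc2n1`) differs from compound 3 by a single change: fluoro in place of hydrogen on an aromatic carbon. Among the compounds with values here, two measured steps bear on this change: a step that the two limits leave unreadable from compound 1 to compound 3, and a step that the two limits leave unreadable from compound 2 to compound 3. Neither gives a size to scale from, and the only firm observation is the limit of > 25000 nM in this assay, at which 3 of the 3 values shown sit. Within the data shown here, no compound in the set goes against it.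

No step beyond the usual scatter is therefore expected, in either direction, and compound 4 is expected to report a limit as well. The expected size is a number no higher from compound 3 to compound 4 (the limit leaves the size open). For compound 4 the estimate is 25000 nM, with an expected range from 10000 nM to 50000 nM.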

Compound 4, half-maximal effective concentration: > 25000 nM
Compound 4 gave a limit, no number; the forecaster's own chance of this, stated with the estimate: 85%; the middle value sits exactly at the limit.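

Compound 4, like compound 3, is reported in this assay only as a limit, so no step can be read between the two. The compounds shown leave open what number, if any, either would reach, and so what the added fluoro changes, with only one firm observation: the limit of > 25000 nM in this assay, at which 4 of the 4 values shown sit.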